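The source may hold more compounds than are shown below. What is called first, only, known or untested is meant among the compounds shown, and "the series" means these compounds.

Of the compounds shown here, three of a shared core have been measured in a functional assay on DU-145 cells (Homo sapiens) for inhibition, read by trypan blue exclusion, with a stated time of 96 h; on this read-out higher numbers stand for weaker inhibition of growth and lower numbers for stronger inhibition of growth. Compound 1 `CCOc1ccc(/C=C(/Sc2ccc(C)cc2)C(=O)c2ccc(Cl)cc2)cc1OC` gives 25000 nM, compound 2 `COc1ccc(C(=O)/C(=C\c2ccc(O)c([N+](=O)[O-])c2)SCc2ccc(Br)cc2)cc1` gives 10000 nM, and compound 3 `O=C(/C(=C\c1c[nH]c2ccc(Br)cc12)SCc1ccc(F)cc1)c1ccc(Cl)cc1` gives 50000 nM. Compound 2 stands lowest of the three; its gaps to compound 1 and to compound 3 both lie beyond the scatter, so it is the strongest inhibitor of growth among them. Compound 4 `O=C(/C(=C\c1ccc(O)c([N+](=O)[O-])c1)SCc1ccc(Br)cc1)c1ccc(Cl)cc1Cl` has not yet been measured. It differs from compound 2 in one place: 2,4-dichlorophenyl in place of 4-methoxyphenyl on a carbonyl carbon. Since both weaker compounds carry a chlorine-bearing ketone aryl ring while differing elsewhere too, no firm direction can be read. The step in this assay is expected to be small, likely within the scatter: compound 4 is estimated at 15000 nM (range 5000 nM to 50000 nM), a step of a 1.5-fold higher number from compound 2 to compound 4 (0.18 log units; within the scatter).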

Compound 4, concentration for 50% growth inhibition: 10000 nM
The estimate for compound 4 lay 1.5-fold (0.18 log units) above the measured number; measured number inside the range.
By their numbers in this assay, from the lowest: compounds 2 and 4 (each within the scatter of the next); then compounds 1 and 3 (each within the scatter of the next).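

In this assay, within the data shown here, placing 2,4-dichlorophenyl in place of 4-methoxyphenyl on a carbonyl carbon gives no change at the digits printed from compound 2 to compound 4 (within the scatter) and is the first comparison here in which only this group differs. With the rest of compound 2 unchanged, either aryl group at this position gives a value within the scatter of the other. Nothing at hand offers an explanation for this result. Still open, going by these compounds, is how the value would respond to a phenyl ring carrying an amine or a carboxylic acid at this position, or to a cyclohexyl group there.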